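Ester to Hydroxycarbamoyl: An Expected Gain in Cell Inhibition

The compounds below may be only part of what the source reports. "The series", "measured", "known", "first", "only" and "open" are said of these compounds alone.

Of the compounds shown here, two sharing one core have been measured in a functional assay on HL-60 cells (Homo sapiens) for antiproliferative activity, tested at 1 uM; on this read-out higher numbers stand for a stronger effect at the one concentration tested and lower numbers for a weaker effect. Compound 1 `CC(=O)Oc1ccc(CONC(=O)c2ccc(CS(=O)(=O)Nc3ccc4cc(C)c(=O)n(C)c4c3)cc2)cc1` gives 3%. Compound 2 `COC(=O)c1ccc(CS(=O)(=O)Nc2ccc3c(c2)cc(C)c(=O)n3C)cc1` gives 15%, the higher of the two numbers; its gap to compound 1 lies beyond the usual scatter, so compound 2 stands as the stronger of the measured pair on this read-out. Among the compounds with values here, no two measured compounds differ in a single place, so no measured step can be reported, and nothing in the numbers so far speaks directly to the change that follows.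

Compound 3 `Cc1cc2cc(NS(=O)(=O)Cc3ccc(C(=O)NO)cc3)ccc2n(C)c1=O` has not yet been measured. It differs from compound 2 in one place: hydroxyamino in place of methoxy on a carbonyl carbon. Cut one bond further out, the methoxycarbonyl of compound 2 becomes a hydroxycarbamoyl in compound 3. Since the two measured numbers do not bear on this change, the size of the step cannot be read from the data; an upward step of a number 35 percentage points higher from compound 2 to compound 3 (beyond the scatter) is nevertheless expected, beyond the scatter. Compound 3 is therefore estimated at 50%, within a range from 15% to 85%.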

Compound 3, a percentage reported as inhibition, at one concentration (the size of the read-out at that concentration, not a potency): 5%
The estimate for compound 3 lay 45 percentage points above the measured number; the measured number lies below the stated range.
By their numbers in this assay, from the lowest: compounds 1, 3 and 2 (each within the scatter of the next, the first and the last beyond it).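

In this assay, within the data shown here, placing hydroxyamino where methoxy stood on a carbonyl carbon gives a number 10 percentage points lower from compound 2 to compound 3 (within the scatter) and so supplies the first measured step at this position, which the earlier compounds could not provide since no two of them differed in one place. Within the scatter, the change from methoxycarbonyl to hydroxycarbamoyl does not separate the two compounds at the one concentration tested, even though two hydrogen-bond donors enter where the methoxy group had none. Nothing available accounts for this outcome.

The compounds shown leave open whether another group on the same carbonyl carbon, such as the hydroxy of a carboxylic acid or the amino of a primary amide, would move the read-out beyond the scatter. They also leave open whether compound 2 and compound 3 would remain this close at other concentrations, since a reading at one concentration is not a measure of potency.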